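A few compounds are considered here, and "the series" means these few. Any claim that something is new, unique, unknown or untested is made for them only; others in the source may bear on it.

Working notes on the series. Among the measured compounds shown here, in a functional assay on HeLa cells (Homo sapiens) for inhibition (a lower number here means a stronger inhibitor, a higher number a weaker inhibitor), compound 2 `Cc1ccc(C(=O)CC(SCC(=O)O)C(=O)O)cc1` gives 17300 nM, the highest of the two numbers so far; its nearest neighbour is compound 1 `Cc1ccc(C(=O)CC(SCC(=O)O)C(=O)O)cc1C`, which in this assay gives 3810 nM. For the measured compounds named here, the one measured step is a 4.5-fold higher number from compound 1 to compound 2 (0.66 log units; beyond the scatter), hydrogen in place of methyl on an aromatic carbon, so within this pair the loss of a methyl from the ring went with a higher number.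

Compound 3 `CC(C)c1ccc(C(=O)CC(SCC(=O)O)C(=O)O)cc1` differs from compound 2 by isopropyl in place of methyl on an aromatic carbon, para to a large group. Going by the values given here, no measured step touches this change directly; the step from compound 1 to compound 2 concerns a methyl at another site of the ring and only shows that this ring tolerates an alkyl there. For isopropyl in place of methyl the data give no direction, and a modest step at most is expected, a 1.7-fold lower number from compound 2 to compound 3 (0.24 log units; within the scatter), close to the scatter. Compound 3 is therefore estimated at 10000 nM in this assay, with a range from 3000 nM to 35000 nM.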

Compound 3, half-maximal inhibitory concentration: 3330 nM
For compound 3 the middle estimate is 3.0-fold (0.48 log units) above the measured one, and the stated range covers the measured number.
By their numbers in this assay, from the lowest: compounds 3 and 1 (each within the scatter of the next); then compound 2.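

This position, on an aromatic carbon para to a large group, now has a direction of its own: in this assay, isopropyl in place of methyl gives a 5.2-fold lower number from compound 2 to compound 3 (0.72 log units; beyond the scatter), so a change with three carbons entering and one leaving goes with a lower number here, and the step is modest but clear of the scatter. The earlier pair spoke only to a methyl at another site of the ring, where the step was a 4.5-fold higher number from compound 1 to compound 2 (0.66 log units; beyond the scatter); compound 2 now stands apart from both neighbours, each of which differs from it in one place and has the lower number, so the two alkyl changes on this ring point the same way in these three compounds. No measurement at hand accounts for the gain at this position.

The compounds shown leave open whether the trend at this position follows the number of carbons or the branching, which ethyl, n-propyl or tert-butyl there would separate. They also leave open how hydrogen, or a non-alkyl group such as chlorine or methoxy, would read at the same carbon.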